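Cyclobutyl in Place of Aminocyclohexyl on a Stable Core

The source may hold more compounds than are shown below. What is called first, only, known or untested is meant among the compounds shown, and "the series" means these compounds.

Compound 1 `Nc1ncnc2c1c(Oc1cc(C(F)(F)F)ccn1)nn2[C@H]1CC[C@@H](N)CC1` was examined in an ADME assay on microsomes from liver (Homo sapiens) for metabolic stability, read by LC-MS, using NADPH, with a stated time of 10 min, tested at 10 uM; a higher number here means that the compound lasts longer, a lower number that the compound disappears faster. In this assay compound 1 gives > 2.41 h, which is a limit of the assay and not a number. Compound 2 `N#Cc1ccnc(Oc2nn(C3CC3)c3ncnc(N)c23)c1` gives > 2.41 h in this assay, again a limit. So far there is only (the limit of > 2.41 h in this assay, at which 2 of the 2 values shown sit), with no measured step between compounds. Compound 3 `Nc1ncnc2c1c(Oc1cc(C(F)(F)F)ccn1)nn2C1CCC1` carries cyclobutyl in place of 4-aminocyclohexyl on an aromatic nitrogen. No change beyond the usual scatter is expected in this assay, so the step that the limit leaves unreadable from compound 1 to compound 3 is expected to be small. Compound 3 is estimated at 2.5 h, with a range of 1.2 h to 5 h.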

Compound 3, half-life: 1.02 h
For compound 3 the middle estimate is 2.5-fold (0.39 log units) above the measured one, and the stated range ends above it.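

In this assay, the group on this aromatic nitrogen proves able to change the read-out: cyclobutyl in place of 4-aminocyclohexyl gives an at least 2.3-fold lower number from compound 1 to compound 3 (0.37 log units; beyond the scatter). Compound 3 is also the first compound shown with a measured half-life rather than a limit. The step therefore gives only a minimum size, since the value of compound 1 is a limit: the limit of > 2.41 h in this assay, at which 2 of the 3 values shown sit.

The compounds shown do not separate the loss of the amine from the change of ring. A plain cyclohexyl or an aminocyclobutyl at this position would address that question.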